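Methylamino for methoxy on the bridged sugar ring

The source may report more compounds than this note shows. Statements on the series, on what has been measured and on what is new or still open speak of the compounds shown alone.

Compound 1 `CNC(=O)C[C@H]1O[C@@](C)(C(=O)OC)n2c3ccccc3c3c4c(c5c6ccccc6n1c5c32)C(=O)NC4` and compound 2 `COC(=O)[C@@]1(OC)C[C@H]2O[C@]1(C)n1c3ccccc3c3c4c(c5c6ccccc6n2c5c31)C(=O)NC4` share the same core and differ in the substituents of their bridged ring. In an assay on isolated protein for inhibition of protein kinase C theta type (Homo sapiens), read by HTRF (a higher number here means a weaker inhibitor, a lower number a stronger inhibitor), compound 1 gives > 2500 nM, which is a limit of the assay rather than a number. Going by the values given here, compound 2 holds the only measured number here; in this assay compound 2 gives 520 nM. Compound 3 `CN[C@]1(C(=O)OC)C[C@H]2O[C@]1(C)n1c3ccccc3c3c4c(c5c6ccccc6n2c5c31)C(=O)NC4` differs from compound 2 by methylamino in place of methoxy on a saturated ring carbon. Among the compounds with values here, no step between two measured compounds is available to size this change. Compound 3 is nevertheless expected to be stronger, with an estimated step of an 8.7-fold lower number from compound 2 to compound 3 (0.94 log units; beyond the scatter). Compound 3 is therefore estimated at 60 nM, with a range from 15 nM to 250 nM.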

Compound 3, half-maximal inhibitory concentration: > 2500 nM
Compound 3: a limit, no number (the forecaster's own chance of this, stated with the estimate: 5%); at least 41-fold (1.61 log units) between middle value and limit.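

Going by these compounds alone, on this saturated ring carbon, methylamino in place of methoxy gives the first step that can be read in this assay: an at least 4.8-fold higher number from compound 2 to compound 3 (0.68 log units; beyond the scatter). Compound 3 gives > 2500 nM, which is a limit of the assay and not a number, so the step has a floor but no measured size: the limit of > 2500 nM in this assay, at which 2 of the 3 values shown sit. The position therefore tolerates this exchange poorly, since a nitrogen-linked methyl costs measurable inhibition that the oxygen-linked methyl retains.

The compounds shown leave open whether a hydroxyl, an ethoxy or a dimethylamino group on this carbon would stay close to compound 2 or also fall to the limit.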